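A few compounds are considered here, and "the series" means these few. Any claim that something is new, unique, unknown or untested is made for them only; others in the source may bear on it.

Three compounds share one core and differ only in the group on an amide-type nitrogen. Compound 1 `CNC(=O)c1ccc(F)c(NCc2cnc(Nc3ccccn3)s2)c1` carries methyl; in a functional assay on L2987 cells (Homo sapiens) for antiproliferative activity (a higher number here means a weaker inhibitor, a lower number a stronger inhibitor), compound 1 reaches only a limit, > 2500 nM. Compound 2 `O=C(NC1CC1)c1ccc(F)c(NCc2cnc(Nc3ccccn3)s2)c1` carries cyclopropyl, and in this assay compound 2 likewise reaches only a limit, > 2500 nM. Compound 3 `O=C(NC1CCCC1)c1ccc(F)c(NCc2cnc(Nc3ccccn3)s2)c1` carries cyclopentyl, and in this assay compound 3 too reaches only a limit, > 2500 nM. The steps a step that the two limits leave unreadable from compound 1 to compound 2, a step that the two limits leave unreadable from compound 1 to compound 3 and a step that the two limits leave unreadable from compound 2 to compound 3 cannot be sized because of the limit of > 2500 nM in this assay, at which 3 of the 3 values shown sit. Compound 4 `O=C(NCc1ccccc1)c1ccc(F)c(NCc2cnc(Nc3ccccn3)s2)c1` differs from compound 3 by benzyl in place of cyclopentyl on an amide-type nitrogen. With no readable step to lean on, compound 4 is expected to remain near that limit, a step that the limit leaves unreadable from compound 3 to compound 4. The estimate for compound 4 is 5000 nM, ranging from 1500 nM to 20000 nM.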

Compound 4, half-maximal inhibitory concentration: > 2500 nM
Compound 4: only a limit was reported (the forecaster's own chance of this, stated with the estimate: 75%); the middle value lies beyond the limit too.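

Within the data shown here, no step to compound 4 from compound 1, compound 2 or compound 3 can be read in this assay, because all four compounds give only a limit: the limit of > 2500 nM in this assay, at which 4 of the 4 values shown sit. The compounds shown leave open whether any group on the amide-type nitrogen gives a measurable value on this core.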